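The compounds below may be only part of what the source reports. "The series", "measured", "known", "first", "only" and "open" are said of these compounds alone.

Of the compounds shown here, three sharing one core have been measured in a functional assay on CCRF-CEM cells (Homo sapiens) for cytotoxicity, read by sulforhodamine B assay, with a stated time of 48 h, tested at 100 uM; on this read-out lower numbers stand for a stronger effect and higher numbers for a weaker effect at the one concentration tested. Compound 1 `COc1ccc(-c2cc(/C=C/C(=O)c3ccc(N)cc3)[nH]n2)cc1` gives -68%. Compound 2 `COc1cc(-c2cc(/C=C/C(=O)c3ccc(N)cc3)[nH]n2)cc(OC)c1OC` gives -21%, the second highest of the three numbers. Compound 3 `COc1cc(-c2cc(/C=C/C(=O)c3ccc(F)c(F)c3)[nH]n2)cc(OC)c1OC` gives -4%. Among the measured compounds shown here, the only measured step, a number 17 percentage points higher from compound 2 to compound 3 (beyond the scatter), lies beyond the scatter, but it exchanges the group on the carbonyl carbon and leaves the methoxy groups untouched, so it does not bear directly on the change now considered. Compound 4 `COc1ccc(-c2cc(/C=C/C(=O)c3ccc(N)cc3)[nH]n2)cc1OC` has not yet been measured. It differs from compound 2 by hydrogen in place of methoxy on an aromatic carbon. For the measured compounds named here, no measured step alters only a methoxy group; compound 1 and compound 2, which differ from each other in two methoxy groups, show numbers that sit far apart, and compound 4 lies between them in structure. Compound 4 is therefore expected to give a number between those two, estimated at -45% with a range from -70% to -15%. The expected step is a number 24 percentage points lower from compound 2 to compound 4 (beyond the scatter), downward and beyond the scatter, though its size is uncertain.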

Compound 4, a percentage reported as activity, at one concentration (the size of the read-out at that concentration, not a potency): -22%
Compound 4: the middle estimate sits 23 percentage points below what was measured; the measured number falls inside the stated range.
By their numbers in this assay, from the lowest: compound 1; then compounds 4 and 2 (each within the scatter of the next); then compound 3.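

In this assay, hydrogen in place of methoxy on the aromatic carbon ortho to a methoxy group and meta to a large group leaves the two compounds indistinguishable (a number 1 percentage points lower from compound 2 to compound 4 (within the scatter)). The other single methoxy change among these compounds, methoxy in place of hydrogen on an aromatic carbon, has a large effect (a number 46 percentage points higher from compound 1 to compound 4 (beyond the scatter)), so the wide gap between compound 1 and compound 2 comes from that step alone, and this position adds nothing measurable to it. No evidence is at hand to explain why the two methoxy changes differ.

On these data alone, it remains open whether a hydroxyl, an ethoxy or a chlorine on this carbon would also leave the number unchanged. Also open, as far as these compounds go, is whether this methoxy change would behave the same way with 3,4-difluorophenyl on the carbonyl carbon, a group carried here only by compound 3.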